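A few compounds are considered here, and "the series" means these few. Any claim that something is new, unique, unknown or untested is made for them only; others in the source may bear on it.

The measured compounds and their values:

Compound 1 `C=CCNc1[nH]nc(N)c1C(=O)Nc1ccc(OCC)cc1` — > 100000 nM
Compound 2 `CCNc1[nH]nc(N)c1C(=O)Nc1ccc(OCC)cc1` — > 100000 nM
Compound 3 `CCNc1[nH]nc2nnn(-c3ccc(OCC)cc3)c(=O)c12` — > 100000 nM

In an ADME assay on TERT-RPE1 cells (Homo sapiens) for cytotoxicity, read by resazurin assay, with a stated time of 48 h (on this read-out lower numbers stand for stronger inhibition and higher numbers for weaker inhibition), compound 1 gives only a limit, > 100000 nM. Compound 2 likewise gives only a limit there, > 100000 nM. Compound 3 also stands at a limit in this assay, > 100000 nM. The difference between compound 2 and compound 1 is vinyl in place of methyl on a saturated chain carbon bound to a nitrogen on an aromatic ring. The step that the two limits leave unreadable from compound 2 to compound 1 cannot be read because of the limit of > 100000 nM in this assay, at which 3 of the 3 values shown sit. How the core of compound 3 differs from that of compound 2 is not broken down here. Compound 4 `C=CCNc1[nH]nc2nnn(-c3ccc(OCC)cc3)c(=O)c12` is not yet measured; it differs from compound 3 by the same change, (vinyl in place of methyl on a saturated chain carbon bound to a nitrogen on an aromatic ring). Compound 4 is expected to stay at the limit, because the limit of > 100000 nM in this assay, at which 3 of the 3 values shown sit, holds for every compound shown, so the estimated step that the limit leaves unreadable from compound 3 to compound 4 is essentially none. Compound 4 is therefore estimated at 150000 nM, ranging 70000 nM to 400000 nM.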

Compound 4, half-maximal inhibitory concentration: > 100000 nM
Compound 4: a limit, no number; the forecaster's own chance of this, stated with the estimate: 85%; the middle value does not contradict the limit.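

No step can be read between compound 3 and compound 4, because each gives only a limit: the limit of > 100000 nM in this assay, at which 4 of the 4 values shown sit. The compounds shown leave open at what concentration, if any, these compounds would inhibit the cells, and whether ethylamino or allylamino makes any difference.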